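This account rests on a few compounds, and the source may have more. Where it says the series, first, only, none or still open, it means among the compounds named here.

Series notes. Compound 1 `O=C(Nc1ccc(I)cc1F)c1cc(I)ccc1O` gives 6000 nM in an ADME assay on RAW264.7 cells (Mus musculus) for cytotoxicity, read by MTT assay, with a stated time of 24 h; a lower number here means that less compound is tolerated, a higher number that more compound is tolerated; compound 2 `O=C(Nc1ccc(I)cc1F)c1cc(F)ccc1O` gives 7400 nM; compound 3 `O=c1oc2ccc(F)cc2c(=O)n1-c1ccc(F)cc1F` gives 19900 nM. Compound 2 stands second highest of the three numbers, nearest to compound 1 and furthest from compound 3, the latter gap beyond the scatter. Compound 4 `O=C(Nc1ccc(Br)cc1F)c1cc(F)ccc1O` differs from compound 2 by bromo in place of iodo on an aromatic carbon. Going by the values given here, the only halogen-for-halogen step measured so far, a 1.2-fold higher number from compound 1 to compound 2 (0.09 log units; within the scatter), moved the number very little. On that basis the change from compound 2 to compound 4 is expected to stay within the scatter, with a 1.1-fold higher number from compound 2 to compound 4 (0.03 log units; within the scatter) as the anticipated step. Compound 4 is therefore estimated at 8000 nM, with a range of 4500 nM to 14000 nM.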

Compound 4, half-maximal cytotoxic concentration: 7900 nM
The estimate for compound 4 lay 1.0-fold (0.01 log units) above the measured number, within the range that was stated.
By their numbers in this assay, from the lowest: compounds 1, 2 and 4 (each within the scatter of the next); then compound 3.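

In this assay, the change of iodo to bromo on the aromatic carbon meta to a fluoro group and para to a large group gives a 1.1-fold higher number from compound 2 to compound 4 (0.03 log units; within the scatter) and stays within the scatter. Going by these compounds alone, the earlier halogen step concerned a different aromatic carbon, so this is the first reading at this position, and here too a halogen exchange leaves compounds unseparated. No measurement at hand bears on the cause of this result. Open, as far as these compounds go, is whether a non-halogen group here, such as an amine, a carboxylic acid or a longer chain, would separate from compound 2.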